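Sulfonylpiperidine series: amide in place of the dioxane ring

A few compounds are considered here, and "the series" means these few. Any claim that something is new, unique, unknown or untested is made for them only; others in the source may bear on it.

Measured values in a functional assay on DLD-1 cells (Homo sapiens) for antiproliferative activity, read by CellTiter-Glo, with a stated time of 72 h; on this read-out higher numbers stand for weaker inhibition and lower numbers for stronger inhibition:
Compound 1 `CC1CCN(C2CCN(S(=O)(=O)c3cn(C)cn3)CC2)CC1` gives > 5000 nM, which is a limit of the assay.
Compound 2 `Cc1cc(C)c(S(=O)(=O)N2CCC(C3OCC(C)CO3)CC2)c(C)c1` gives > 5000 nM, also a limit of the assay.
Compound 3 `Cc1cc(C)cc(-c2cccc(S(=O)(=O)N3CCC(N4CCC(C)CC4)CC3)c2)c1` gives 41 nM.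

Compound 2 therefore has no number of its own in this assay, only the boundary; compound 1 sits at the same boundary (the limit of > 5000 nM in this assay, at which 2 of the 3 values shown sit). For the measured compounds named here, compound 3 is the single compound with a measured number, and no single-point change connects it to compound 2, so the two values are noted side by side without a step being drawn between them.

The change to compound 4 `Cc1cc(C)c(S(=O)(=O)N2CCC(C(=O)N3CCC(C)CC3)CC2)c(C)c1` is this: a group of 9 heavy atoms (7 carbon, 1 nitrogen, 1 oxygen; one six-membered non-aromatic ring with 1 hetero atom) in place of a group of 7 heavy atoms (5 carbon, 2 oxygen; one six-membered non-aromatic ring with 2 hetero atoms), on a saturated ring carbon. The trimethylphenyl sulfonyl part and the piperidine carrying the large group are kept; only the group on the saturated ring carbon is exchanged for the (4-methylpiperidin-1-yl)carbonyl.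

Going by the values given here, no measured pair shows this kind of exchange, so the size of the step rests on nothing measured. Compound 2 starts at the limit, and the expected step is a step that the limit leaves unreadable from compound 2 to compound 4, i.e. none beyond the scatter. Compound 4 is estimated at 8000 nM, within the range 2000 nM to 30000 nM, with a limit rather than a number the more likely outcome.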

Compound 4, half-maximal inhibitory concentration: > 5000 nM
Compound 4: no number, only a limit; the forecaster's own chance of this, stated with the estimate: 65%; the middle value lies beyond the limit too.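

No step can be read from compound 2 to compound 4 in this assay, because both values are limits of the assay and not numbers: the limit of > 5000 nM in this assay, at which 3 of the 4 values shown sit.

Left open is whether the (4-methylpiperidin-1-yl)carbonyl group and the group it replaces differ in activity at all, and which single-place change links these compounds to compound 3 at 41 nM.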